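Methoxy for Methyl on a Weak Retinoid Acid

A few compounds are considered here, and "the series" means these few. Any claim that something is new, unique, unknown or untested is made for them only; others in the source may bear on it.

Measured compounds:
compound 1, `CC1(C)CCC(C)(C)c2cc(-c3ccc(/C=C/C(=O)O)o3)ccc21`: 93 nM
compound 2, `Cc1cc2c(cc1C1CCCc3oc(/C=C/C(=O)O)cc31)C(C)(C)CCC2(C)C`: > 1000 nM

Of the compounds shown here, two have been measured in an assay on isolated protein for binding affinity to retinoic acid receptor alpha (Homo sapiens); on this read-out lower numbers stand for stronger inhibition and higher numbers for weaker inhibition. Compound 1 (`CC1(C)CCC(C)(C)c2cc(-c3ccc(/C=C/C(=O)O)o3)ccc21`) gives 93 nM. Compound 2 (`Cc1cc2c(cc1C1CCCc3oc(/C=C/C(=O)O)cc31)C(C)(C)CCC2(C)C`) is reported only as a limit of the assay, > 1000 nM. That reading is described as the limit of > 1000 nM in this assay, at which 1 of the 2 values shown sits. The two compounds are not joined by a change in a single place, so their values can only be set side by side: compound 1 has a number, compound 2 sits at the limit.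

Compound 3 (`COc1cc2c(cc1C1CCCc3oc(/C=C/C(=O)O)cc31)C(C)(C)CCC2(C)C`) differs from compound 2 in one place: methoxy in place of methyl on an aromatic carbon. Among the measured compounds shown here, no measured step shows how such an exchange moves the value. The step from compound 2 to compound 3 in this assay is therefore expected to be small, with no direction beyond the scatter: a step that the limit leaves unreadable from compound 2 to compound 3. Compound 3 is expected to give 1500 nM, with a range from 500 nM to 5000 nM. A reported limit rather than a number remains the more likely outcome for compound 3.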

Compound 3, inhibition constant: > 1000 nM
Compound 3: no number, only a limit (the forecaster's own chance of this, stated with the estimate: 60%); the middle value lies beyond the limit too.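

In this assay, among the compounds shown here, compound 2 and compound 3 are both reported only as limits of the assay, so no step between them can be read, because neither compound has a number: the limit of > 1000 nM in this assay, at which 2 of the 3 values shown sit. From the compounds shown here alone, whether methoxy in place of methyl on an aromatic carbon moves the value at all, and in which direction, stays open.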